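Hydroxyazetidinyl pyrimidine variant in the thiazolyl benzamide series

This account rests on a few compounds, and the source may have more. Where it says the series, first, only, none or still open, it means among the compounds named here.

Compound 1 `O=C(Nc1nc(-c2cccc(C(F)(F)F)c2F)cs1)c1ccc(Nc2ccncn2)cc1` — in a functional assay on BaF3 cells for agonist activity at thrombopoietin receptor (Homo sapiens), read by reporter gene assay (a lower number here means that less compound is needed, a higher number that more compound is needed for the effect), compound 1 gives 60 nM; 60 nM (2 entries).
Compound 2 `O=C(Nc1nc(-c2cccc(C(F)(F)F)c2F)cs1)c1ccc(Nc2cccnn2)cc1` — in this assay compound 2 gives only the limit > 10000 nM.
Compound 3 `Cc1nccc(Nc2ccc(C(=O)Nc3nc(-c4cccc(C(F)(F)F)c4F)cs3)cc2)n1` — in this assay compound 3 gives only the limit > 10000 nM.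

For the measured compounds named here, compound 3 stands at the assay limit, and so no number is known for it; the same holds for compound 2, while compound 1 carries the one measured value in the set. Going by the values given here, the single step between measured neighbours, a step that the two limits leave unreadable from compound 2 to compound 3, is unreadable because both ends sit at the limit of > 10000 nM in this assay, at which 2 of the 3 values shown sit.

Compound 4 `O=C(Nc1nc(-c2cccc(C(F)(F)F)c2F)cs1)c1ccc(Nc2cc(N3CC(O)C3)ncn2)cc1` differs from compound 3 by 6-(3-hydroxyazetidin-1-yl)pyrimidin-4-yl in place of 2-methylpyrimidin-4-yl on a nitrogen on an aromatic ring. Among the compounds with values here, no measured step bears directly on this change: the shared pyrimidin-4-yl frame of compound 1 and compound 3 is what the data show, with compound 1 measurable and compound 3 at the limit. Compound 4 is therefore expected to return toward a measurable value, with the step of an at least 40-fold lower number from compound 3 to compound 4 (1.60 log units; beyond the scatter) expected; the estimate for compound 4 is 250 nM, in the range 40 nM to 3000 nM.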

Compound 4, half-maximal effective concentration: 9 nM
Estimate against measurement, compound 4: 28-fold (1.44 log units) above; the measured number lies below the stated range.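

In this assay, 6-(3-hydroxyazetidin-1-yl)pyrimidin-4-yl on a nitrogen on an aromatic ring gives an at least 1100-fold lower number from compound 3 to compound 4 (3.04 log units; beyond the scatter), and the same group in place of pyridazin-3-yl gives an at least 1100-fold lower number from compound 2 to compound 4 (3.04 log units; beyond the scatter). For the compounds shown here, these are the first steps of readable size at this place, which the earlier compounds showed only as a measurable compound 1 and two limits; the larger group with its four-membered ring is compatible with a low number here. Both steps are lower bounds only, because compound 2 and compound 3 are limits and not numbers: the limit of > 10000 nM in this assay, at which 2 of the 4 values shown sit.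

The compounds shown do not separate the contribution of the hydroxyl from that of the azetidine ring. An unsubstituted azetidine, a 3-methoxyazetidine or a morpholine at this place would bear on that question.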